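The source may hold more compounds than are shown below. What is called first, only, known or untested is meant among the compounds shown, and "the series" means these compounds.

Measured compounds:
compound 1, `CCC1C(=O)N(C)c2cnc(Nc3ccc(S(=O)(=O)NCC(C)C)cc3)nc2N1c1ccn(C)n1`, 8520 nM
compound 2, `CCCCNS(=O)(=O)c1ccc(Nc2ncc3c(n2)N(c2ccn(C)n2)C(CC)C(=O)N3C)cc1`, 3750 nM
compound 3, `CCCCNC(=O)c1ccc2c(ccn2-c2ncc3c(n2)N(C2CCCC2)[C@H](CC)C(=O)N3C)c1`, 683 nM

In a functional assay on Huh-7 cells (Homo sapiens) for antiproliferative activity, read by CCK-8 assay, with a stated time of 72 h (on this read-out lower numbers stand for stronger inhibition of growth and higher numbers for weaker inhibition of growth), compound 3 gives the lowest of the three numbers, and compound 1 the highest. Compound 2 and compound 1 differ in one place, (isopropyl in place of propyl on a saturated chain carbon bound to a sulfonamide nitrogen), and that change made a step of a 2.3-fold higher number from compound 2 to compound 1 (0.36 log units; beyond the scatter). Compound 3 and compound 2 are built on different cores; the difference between the two cores is not broken down here.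

Compound 4, `CC[C@@H]1C(=O)N(C)c2cnc(-n3ccc4cc(C(=O)NCC(C)C)ccc43)nc2N1C1CCCC1`, has not yet been tested. It differs from compound 3 in one place, (isopropyl in place of propyl on a saturated chain carbon bound to an amide-type nitrogen). Among the measured compounds shown here, this is the same kind of change as the one from compound 2 to compound 1, but not the same: there the carbon was bound to a sulfonamide nitrogen, here it is bound to an amide-type nitrogen. Resting on the step from compound 2 to compound 1, a 2.3-fold higher number from compound 2 to compound 1 (0.36 log units; beyond the scatter), an expected step for compound 4 is a 2.0-fold higher number from compound 3 to compound 4 (0.31 log units; beyond the scatter), with a wider range because the surroundings differ. Compound 4 is therefore estimated at 1400 nM, expected between 600 nM and 3500 nM.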

Compound 4, concentration for 50% growth inhibition: "not active" (no number reported)
Compound 4: no number reported; no gap can be computed for the estimate.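

In this assay, among the compounds shown here, compound 4 is reported as not active, with no number given, so no step from compound 3 to compound 4 can be read. Nothing shown here bears on this result. The compounds shown leave open how large the effect of the single change from compound 3 to compound 4 is.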